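Swapping the biaryl sulfonamide arm in a shared series

A few compounds are considered here, and "the series" means these few. Any claim that something is new, unique, unknown or untested is made for them only; others in the source may bear on it.

Compound 1 `COc1cc2c(Oc3ccc(NS(=O)(=O)c4cccc(-c5cnn(C)c5)c4)cc3F)ccnc2cc1OCCCN1CCN(C)CC1` and compound 2 `COc1cc2c(Oc3ccc(NS(=O)(=O)c4cccc(-c5ccsc5)c4)cc3F)ccnc2cc1OCCCN1CCN(C)CC1` were tested in an ADME assay on NIH3T3 cells (Mus musculus) for cytotoxicity, read by MTT assay, with a stated time of 48 h; a higher number here means a weaker inhibitor, a lower number a stronger inhibitor. Compound 1 gives 2480 nM in this assay, and compound 2 gives 2350 nM; the step of a 1.1-fold lower number from compound 1 to compound 2 (0.02 log units; within the scatter) brought thiophen-3-yl in place of 1-methyl-1H-pyrazol-4-yl on an aromatic carbon. Compound 3 `COc1cc2c(Oc3ccc(NS(=O)(=O)c4cc(-c5ccsc5)ccc4F)cc3F)ccnc2cc1OCCCN1CCN(C)CC1` has no number in this assay, its entry reading "not determined" (no result reported). Compound 4 `COc1cc2c(Oc3ccc(NS(=O)(=O)c4cccc(-c5ccco5)c4)cc3F)ccnc2cc1OCCCN1CCN(C)CC1` differs from compound 3 by 3-(furan-2-yl)phenyl in place of 2-fluoro-5-(thiophen-3-yl)phenyl on a sulfonyl sulfur. For the measured compounds named here, no measured step maps onto this change; the only measured step, exchanging one five-membered aromatic ring for another, stayed within the scatter, and compound 3 offers no anchor. Compound 4 is therefore expected to sit near compounds 1 and 2 in this assay, estimated at 2400 nM, within a range of 1100 nM to 5200 nM.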

Compound 4, half-maximal inhibitory concentration: 3200 nM
For compound 4 the middle estimate is 1.3-fold (0.12 log units) below the measured one; low and high end bracket the measured number.
By their numbers in this assay, from the lowest: compounds 2, 1 and 4 (each within the scatter of the next).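

In this assay, furan-2-yl on this aromatic carbon brought a 1.4-fold higher number from compound 2 to compound 4 (0.13 log units; within the scatter) in place of thiophen-3-yl and a 1.3-fold higher number from compound 1 to compound 4 (0.11 log units; within the scatter) in place of 1-methyl-1H-pyrazol-4-yl. For the compounds shown here, three different five-membered aromatic rings now stand within the scatter of one another at this place, where earlier only one pair could be compared. Nothing at hand bears on what lies behind this result. On these data alone, the step from compound 3 to compound 4 cannot be read, and whether an amine or a carboxylic acid in place of the five-membered ring would move the number beyond the scatter stays open.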